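Methylation of the Aryl Nitrogen in Two Diarylamine Series

The compounds below may be only part of what the source reports. "The series", "measured", "known", "first", "only" and "open" are said of these compounds alone.

Compound 1 `COc1cccc(Nc2ccc(NC(=O)C(C)C)cc2)c1` was tested in an assay on isolated protein for binding affinity to melatonin receptor type 1A (Homo sapiens) (a lower number here means a stronger inhibitor, a higher number a weaker inhibitor), where compound 1 gives > 500 nM, a limit of the assay rather than a number. Compound 2 `COc1cccc(N(C)c2ccc(NC(=O)C(C)C)cc2)c1` gives 106 nM in this assay. The step of an at least 4.7-fold lower number from compound 1 to compound 2 (0.67 log units; beyond the scatter) follows from methyl in place of hydrogen on a nitrogen on an aromatic ring. Compound 3 `CCCC(=O)Nc1ccc(Nc2cccc3c2CCO3)cc1` gives > 500 nM in this assay, again a limit and not a number. How the core of compound 3 differs from the core of compound 1 is not broken down here. Among the compounds with values here, compound 4 `CCCC(=O)Nc1ccc(N(C)c2cccc3c2CCO3)cc1` arises from compound 3 by methyl in place of hydrogen on a nitrogen on an aromatic ring, the same change as the one between compound 1 and compound 2, at a place described in the same words. The expected step is an at least 2.5-fold lower number from compound 3 to compound 4 (0.39 log units; beyond the scatter), resting on an at least 4.7-fold lower number from compound 1 to compound 2 (0.67 log units; beyond the scatter) and on (the limit of > 500 nM in this assay, at which 2 of the 3 values shown sit), which leaves the true starting point of compound 3 open. Compound 4 is estimated at 200 nM, between 60 nM and 800 nM.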

Compound 4, inhibition constant: 36 nM
Beside the measured number, compound 4's estimate is 5.6-fold (0.74 log units) above it; measured number outside the range, below it.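

In this assay, methyl in place of hydrogen on a nitrogen on an aromatic ring gives an at least 13-fold lower number from compound 3 to compound 4 (1.14 log units; beyond the scatter), so the change lowers the number on both cores shown. This shows that the direction carries from the core of compound 1 to the core of compound 3, but it does not show that the size carries, and the two steps cannot be ranked: the same change on two cores in this assay, an at least 4.7-fold lower number (0.67 log units; beyond the scatter) from compound 1 to compound 2 and an at least 13-fold lower number (1.14 log units; beyond the scatter) from compound 3 to compound 4; the limit leaves it open whether they differ. On these data alone, each step starts from a limit rather than a number, so its true size remains unknown: the limit of > 500 nM in this assay, at which 2 of the 4 values shown sit.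

As far as these compounds go, whether an ethyl group or a longer chain on the same nitrogen would lower the number as well remains open. So does whether the step would hold on a third core.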